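From 3-fluorophenyl to 3-nitrophenyl: working notes

This account rests on a few compounds, and the source may have more. Where it says the series, first, only, none or still open, it means among the compounds named here.

Three compounds on the shared core have numbers in a functional assay on MCF7 cells (Homo sapiens) for antiproliferative activity, read by MTT assay, with a stated time of 72 h; a higher number here means a weaker inhibitor, a lower number a stronger inhibitor. Compound 1 (`COc1cc(-n2cnc3ccc(-c4ccc(C(F)(F)F)cc4)cc32)cc(OC)c1OC`) gives 760 nM, compound 2 (`COc1cc(-n2cnc3ccc(-c4cccc(O)c4)cc32)cc(OC)c1OC`) gives 350 nM and compound 3 (`COc1cc(-n2cnc3ccc(-c4cccc(F)c4)cc32)cc(OC)c1OC`) gives 2350 nM. Compound 3 therefore has the highest number of the three and is the weakest inhibitor in this small set.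

The next structure is compound 4 (`COc1cc(-n2cnc3ccc(-c4cccc([N+](=O)[O-])c4)cc32)cc(OC)c1OC`), with nitro in place of fluoro on an aromatic carbon, meta to a large group: nitro in place of fluoro on an aromatic carbon.

The closest measured evidence changes the same place, where fluoro in place of hydroxy gave a 6.7-fold higher number from compound 2 to compound 3 (0.83 log units; beyond the scatter). The other two steps change the aryl group as a whole: a 2.2-fold lower number from compound 1 to compound 2 (0.34 log units; beyond the scatter) and a 3.1-fold higher number from compound 1 to compound 3 (0.49 log units; beyond the scatter). Going by the values given here, all three are modest, and no measured compound carries nitro, so the size of the next step is poorly fixed. Compound 3 stands highest, so a move down in this assay is expected, though probably a smaller one than the step to the hydroxy compound. The expected change is a 2.6-fold lower number from compound 3 to compound 4 (0.42 log units; beyond the scatter). For compound 4 the estimated value is 900 nM, with an expected range from 280 nM to 2900 nM.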

Compound 4, half-maximal inhibitory concentration: 4560 nM
The estimate for compound 4 lay 5.1-fold (0.70 log units) below the measured number; measured number above the stated range.
By their numbers in this assay, from the lowest: compound 2; then compound 1; then compounds 3 and 4 (each within the scatter of the next).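

In this assay, nitro in place of fluoro on this aromatic carbon gives a 1.9-fold higher number from compound 3 to compound 4 (0.29 log units; within the scatter), so these two groups cannot be told apart here, despite the difference in heavy atoms and hydrogen-bond acceptors. Among the three groups on this carbon, hydroxy now stands alone: nitro in its place gives a 13-fold higher number from compound 2 to compound 4 (1.11 log units; beyond the scatter), in the same direction as a 6.7-fold higher number from compound 2 to compound 3 (0.83 log units; beyond the scatter), and the whole-aryl comparison gives a 6.0-fold higher number from compound 1 to compound 4 (0.78 log units; beyond the scatter), which places compound 4 on the same side of compound 1 as compound 3. Nothing beyond the assay numbers bears on why these steps take this form.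

On these data alone, whether an amine or a carboxylic acid on the same aromatic carbon would stay close to compound 2 or fall with compounds 3 and 4 remains open. Also open, as far as these compounds go, is whether a methoxy group there, which keeps the oxygen of hydroxy but not its hydrogen, would retain the lower number of compound 2, and so whether that number depends on the hydroxy hydrogen at all.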